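The source may hold more compounds than are shown below. What is called first, only, known or untested is meant among the compounds shown, and "the series" means these compounds.

In a functional assay on A549 cells (Homo sapiens) for inhibition, read by MTT assay, with a stated time of 72 h (a higher number here means a weaker inhibitor, a lower number a stronger inhibitor), compound 1 `CC1=NN(c2ccccc2)C(=O)[C@]12C(=O)C=CC[C@@H]2c1ccc(C)cc1` gives 8600 nM and lies within the scatter of the other two measured compounds: compound 2 `CC1=NN(c2ccccc2)C(=O)[C@]12C(=O)C=CC[C@@H]2c1cccc(C)c1` gives 4770 nM and compound 3 `CC1=NN(c2ccccc2)C(=O)[C@]12C(=O)C=CC[C@@H]2c1ccccc1` gives 9180 nM in the same read-out, so the three cannot be ranked. Compound 4 `CC1=NN(c2ccc(C)cc2)C(=O)[C@]12C(=O)C=CC[C@@H]2c1ccc(C)cc1` differs from compound 1 by methyl in place of hydrogen on an aromatic carbon as a change of phenyl to 4-methylphenyl: methyl in place of hydrogen on an aromatic carbon, para to a large group.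

The closest measured evidence is the same exchange run in reverse on a different aromatic ring. Here a 1.1-fold higher number from compound 1 to compound 3 (0.03 log units; within the scatter) and a 1.9-fold higher number from compound 2 to compound 3 (0.28 log units; within the scatter) both stay within the scatter, as does a 1.8-fold lower number from compound 1 to compound 2 (0.26 log units; within the scatter) for the shifted methyl. Among the compounds with values here, no measured step touches the phenyl that changes in compound 4, so this support is indirect.

No step beyond the scatter is therefore expected in this assay in either direction. The estimated step is a 1.2-fold lower number from compound 1 to compound 4 (0.09 log units; within the scatter) and no more than that. For compound 4 the estimated value is 7000 nM with an expected range from 3500 nM to 14000 nM as its bounds.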

Compound 4, half-maximal inhibitory concentration: 54300 nM
The estimate for compound 4 lay 7.8-fold (0.89 log units) below the measured number, outside the stated range (above it).
By their numbers in this assay, from the lowest: compounds 2, 1 and 3 (each within the scatter of the next); then compound 4.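

In this assay, within the data shown here, methyl in place of hydrogen on the phenyl that becomes 4-methylphenyl gives a 6.3-fold higher number from compound 1 to compound 4 (0.80 log units; beyond the scatter), the first step beyond the scatter. This position therefore responds to a methyl, whereas the earlier methyl exchanges on the other aromatic ring all stayed within the scatter. A step read on one aromatic ring does not carry over to the other: the same change on two cores in this assay, a 1.9-fold higher number (0.28 log units; within the scatter) from compound 2 to compound 3 and a 6.3-fold lower number (0.80 log units; beyond the scatter) from compound 4 to compound 1, 12-fold (1.08 log units) apart, beyond the scatter of two such steps

On these data alone, the step rests on a single pair, read only with 4-methylphenyl on the saturated ring carbon, so its size on the core of compound 3 stays open. Also open, as far as these compounds go, is whether a chlorine, a methoxy group, an amine or a longer alkyl chain at this same place would give a step of similar size.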